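A Rearranged Guanidine Tail on a Phenyl-Bearing Core

The source may hold more compounds than are shown below. What is called first, only, known or untested is meant among the compounds shown, and "the series" means these compounds.

The read-out here is a functional assay on the whole organism with Rattus norvegicus as the target, at a dose of 100 mg/kg; on this read-out higher numbers stand for more inhibition at the one dose given (going by the name of the read-out) and lower numbers for less inhibition. Of the compounds shown here, two have been measured. Compound 1 `C/N=C(/NC#N)NCCCCn1nc(N(C)C)ccc1=O` gives 26.3% in this assay. Compound 2 `CN(C)/C(=N/CCCCn1nc(-c2ccccc2)ccc1=O)NC#N` gives 80.7% in this assay, the highest of the two numbers, and its nearest neighbour is compound 1, whose number is lower by a margin beyond the scatter. The two differ in more than one place, so no single change can be tied to that gap; the numbers only show that compound 2 stands well above compound 1.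

Compound 3 `CC/N=C(/NC#N)NCCCCn1nc(-c2ccccc2)ccc1=O` keeps the core of compound 2 and rearranges the tail: a group of 8 heavy atoms (4 carbon, 4 nitrogen; no ring) in place of a group of 8 heavy atoms (4 carbon, 4 nitrogen; no ring), on a saturated chain carbon, four bonds along the chain from an aromatic nitrogen. The same atoms are joined differently, so the change is modest in kind. For the measured compounds named here, with no single-change step measured, a small downward move in this assay is expected, close to the scatter, since compound 1 carries a tail of the same kind and gives 26.3% while differing on the core as well. Compound 3 is expected to give 60% in this assay, within 30% to 85%. The expected step is a number 20.7 percentage points lower from compound 2 to compound 3 (beyond the scatter).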

Compound 3, a percentage reported as inhibition, in the whole organism at one dose (the size of the read-out at that dose, not a potency): 58.8%
Estimate against measurement, compound 3: 1.2 percentage points above; the range from low to high includes it.
By their numbers in this assay, from the lowest: compound 1; then compound 3; then compound 2.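

For the compounds shown here, this is the first pair of compounds that differ in one place only, so the tail on the saturated chain carbon, four bonds along the chain from an aromatic nitrogen, can be judged on its own. In this assay the rearrangement gives a number 21.9 percentage points lower from compound 2 to compound 3 (beyond the scatter) with the core left unchanged. The two tails hold the same atoms, with 1 hydrogen-bond donor in the group that leaves and 2 hydrogen-bond donors in the group that enters, which shows that the way the atoms are joined at this position can move the read-out, although nothing at hand explains the drop.

Compound 1 differs from both of the others in more than one place, so it cannot show whether the same rearrangement would change the number in the same way on a different core. Going by these compounds, what a longer chain would do at this position also remains open, as does the result of putting an amine or a carboxylic acid in place of the whole tail.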